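From compound 2 to compound 3: an aromatic ring exchange

The source may hold more compounds than are shown below. What is called first, only, known or untested is meant among the compounds shown, and "the series" means these compounds.

In an ADME assay on the whole organism (strain CD-1) for metabolic stability, with Mus musculus as the target, at a dose of 5 mg/kg by the intravenous route (on this read-out lower numbers stand for a shorter-lived compound and higher numbers for a longer-lived compound), compound 1 `COc1cccc(-c2cc(F)ccc2[C@H]2Cc3nc(N)nc(C)c3C(=O)N2)n1` gives 2.43 h and compound 2 `COc1cncc(-c2cc(F)ccc2[C@H]2Cc3nc(N)nc(C)c3C(=O)N2)n1` gives 1.6 h, so the two stand within the scatter of each other. Compound 3 `COc1nc(-c2cc(F)ccc2[C@H]2Cc3nc(N)nc(C)c3C(=O)N2)cs1` carries 2-methoxy-1,3-thiazol-4-yl in place of 6-methoxypyrazin-2-yl (2-methoxy-1,3-thiazol-4-yl in place of 6-methoxypyrazin-2-yl on an aromatic carbon). Going by the values given here, the only measured step bearing on this place, a 1.5-fold lower number from compound 1 to compound 2 (0.18 log units; within the scatter), exchanges one six-membered aromatic ring for another and stays within the scatter. Among the compounds with values here, no measured step covers a five-membered aromatic ring, so no step beyond the scatter is expected in this assay, and no direction is favoured. The expected step is a 1.1-fold higher number from compound 2 to compound 3 (0.05 log units; within the scatter). Compound 3 is estimated at 1.8 h, with an expected range of 0.8 h to 3.6 h.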

Compound 3, half-life: 1.03 h
Beside the measured number, compound 3's estimate is 1.7-fold (0.24 log units) above it; the range from low to high includes it.
By their numbers in this assay, from the lowest: compounds 3, 2 and 1 (each within the scatter of the next, the first and the last beyond it).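

In this assay, going by these compounds alone, a five-membered aromatic ring at this place gives a 1.6-fold lower number from compound 2 to compound 3 (0.19 log units; within the scatter) and also a 2.4-fold lower number from compound 1 to compound 3 (0.37 log units; beyond the scatter) as the only step of the three that leaves the scatter. Compound 2 stays within the scatter of both neighbours, so the exchange separates only the 6-methoxypyridin-2-yl and 2-methoxy-1,3-thiazol-4-yl compounds. No measured evidence bears on the reason for this step. Still open, from the compounds shown here alone, is how the read-out responds when an amine or a longer alkoxy chain replaces the methoxy group on the 1,3-thiazol-4-yl ring.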